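A Phosphorus Configuration Governs Half-Life in Blood

The source may hold more compounds than are shown below. What is called first, only, known or untested is meant among the compounds shown, and "the series" means these compounds.

Compound 1 `CCc1cc(C(=O)OCO[P@@]2(=O)OCC(C)(C)[C@H](C(=O)NCCC(=O)OC)O2)n(C)n1` was studied in an ADME assay on blood (Homo sapiens) for pharmacokinetics; a higher number here means that the compound lasts longer, a lower number that the compound disappears faster. In this assay compound 1 gives >= 0.97 h, which is a limit of the assay rather than a number. Compound 2 `COC(=O)CCNC(=O)[C@@H]1O[P@@](=O)(OCOC(=O)c2cc(C(C)(C)C)n[nH]2)OCC1(C)C` carries 3-(tert-butyl)-1H-pyrazol-5-yl in place of 3-ethyl-1-methyl-1H-pyrazol-5-yl on a carbonyl carbon. In this assay compound 2 gives > 1 h, again a limit of the assay. The step that the two limits leave unreadable from compound 1 to compound 2 therefore cannot be read, as the limit of > 1 h in this assay, at which 1 of the 3 values shown sits, and the limit of >= 0.97 h in this assay, at which 1 of the 3 values shown sits, show. Compound 3 `CCc1cc(C(=O)OCO[P@]2(=O)OCC(C)(C)[C@H](C(=O)NCCC(=O)OC)O2)n(C)n1` shares all atoms and bonds with compound 1; the two cores differ in that (the two compounds have the same atoms and bonds and differ only in configuration as drawn: 1 of 2 stereo elements differ; a stereocentre at a phosphorus is drawn S in compound 1 and R in compound 3). In this assay compound 3 gives < 0.16 h, a limit of the assay. The step of an at least 6.0-fold lower number from compound 1 to compound 3 (0.78 log units; beyond the scatter) rests on the fact that compounds 1 and 3 differ only in the configuration as drawn together with the limit of < 0.16 h in this assay, at which 1 of the 3 values shown sits. Compound 4 `COC(=O)CCNC(=O)[C@@H]1O[P@](=O)(OCOC(=O)c2cc(C(C)(C)C)n[nH]2)OCC1(C)C` is not yet measured; it relates to compound 3 by the same change seen between compounds 1 and 2, namely (3-(tert-butyl)-1H-pyrazol-5-yl in place of 3-ethyl-1-methyl-1H-pyrazol-5-yl on a carbonyl carbon). Compound 4 is expected to move by a step that the limit leaves unreadable from compound 3 to compound 4, because the step that the two limits leave unreadable from compound 1 to compound 2 gave no readable change while the configuration at phosphorus is kept from compound 3. For compound 4 the estimated half-life is 0.15 h, between 0.05 h and 0.5 h.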

Compound 4, half-life: < 0.16 h
Compound 4: a limit, no number; the forecaster's own chance of this, stated with the estimate: 60%; the middle value does not contradict the limit.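

In this assay compound 4 gives < 0.16 h, which is a limit of the assay. The exchange of 3-ethyl-1-methyl-1H-pyrazol-5-yl for 3-(tert-butyl)-1H-pyrazol-5-yl cannot be read on either core, as both pairs end in limits, so the data do not show whether the change has the same size on the core of compound 1 and the core of compound 3. What does carry over is the effect of the configuration at phosphorus, since an at least 6.2-fold lower number from compound 2 to compound 4 (0.79 log units; beyond the scatter) stands beside an at least 6.0-fold lower number from compound 1 to compound 3 (0.78 log units; beyond the scatter), and this reading rests on two matched pairs, the second of which is given by this: the fact that compounds 2 and 4 differ only in the configuration as drawn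

Going by these compounds, all four values are limits, so the actual half-lives and the true size of both steps stay open. Also open, on these data alone, is whether the phosphorus configuration has the same effect when an amine or a longer chain takes the place of the pyrazole on the carbonyl carbon.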